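From thiophen-3-yl to 1-benzofuran-2-yl on a shared core

This account rests on a few compounds, and the source may have more. Where it says the series, first, only, none or still open, it means among the compounds named here.

In a functional assay on HL-60 cells (Homo sapiens) for antiproliferative activity, read by XTT assay, with a stated time of 72 h (on this read-out higher numbers stand for weaker inhibition and lower numbers for stronger inhibition), compound 1 `Nc1nc2c(c(-c3cccs3)cn2[C@@H]2O[C@H](CO)[C@@H](O)[C@H]2O)c(=O)[nH]1` gives > 20000 nM as a limit. Compound 2 `Nc1nc2c(c(-c3ccsc3)cn2[C@@H]2O[C@H](CO)[C@@H](O)[C@H]2O)c(=O)[nH]1` gives > 20000 nM as a limit too. Among the compounds with values here, the one measured step that the two limits leave unreadable from compound 1 to compound 2 offers no size to carry forward, and the limit of > 20000 nM in this assay, at which 2 of the 2 values shown sit, is all the numbers show. Compound 3 `Nc1nc2c(c(-c3cc4ccccc4o3)cn2[C@@H]2O[C@H](CO)[C@@H](O)[C@H]2O)c(=O)[nH]1` brings the change 1-benzofuran-2-yl in place of thiophen-3-yl on an aromatic carbon on the same core. Compound 2 offers only > 20000 nM as a limit to start from, so no clear step is expected in this assay in either direction. The step expected is a number no higher from compound 2 to compound 3 (the limit leaves the size open) by this estimate. For compound 3 the expected value is 20000 nM within an estimated range of 6000 nM to 60000 nM for now.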

Compound 3, half-maximal inhibitory concentration: > 20000 nM
Compound 3 ended at the assay's limit (the forecaster's own chance of this, stated with the estimate: 70%); the middle value sits exactly at the limit.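

In this assay the steps from compound 2 to compound 3 and from compound 1 to compound 3 cannot be read, and all three results are limits: the limit of > 20000 nM in this assay, at which 3 of the 3 values shown sit. The compounds shown leave open how strongly each inhibits and whether thiophen-2-yl, thiophen-3-yl and 1-benzofuran-2-yl differ at all on the shared core.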